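Replacing the Dichlorophenyl Urea with a tert-Butyl Isoxazole

A few compounds are considered here, and "the series" means these few. Any claim that something is new, unique, unknown or untested is made for them only; others in the source may bear on it.

Compound 3 `O=C(Nc1ccc(Nc2ncnc3c2OCCN3)cc1)Nc1cc(Cl)cc(Cl)c1` gives 1300 nM in an assay on isolated protein for inhibition of proto-oncogene tyrosine-protein kinase receptor Ret variant V804M (Homo sapiens), read by 33P incorporation, with stated times of 15 min and 40 min (a lower number here means a stronger inhibitor, a higher number a weaker inhibitor), the second highest of the three numbers. Compound 2 `Cc1cc(C)cc(NC(=O)Nc2ccc(Nc3ncnc4c3OCCN4)cc2)c1` gives 971 nM, and compound 1 `O=C(Nc1ccc(Br)cc1)Nc1ccc(Nc2ncnc3c2OCCN3)cc1` gives 2350 nM; the steps of a 1.8-fold lower number from compound 1 to compound 3 (0.26 log units; within the scatter) and a 1.3-fold higher number from compound 2 to compound 3 (0.13 log units; within the scatter) both lie within the scatter, while a 2.4-fold lower number from compound 1 to compound 2 (0.38 log units; beyond the scatter) is modest. Compound 4 `CC(C)(C)c1cc(NC(=O)Nc2ccc(Nc3ncnc4c3OCCN4)cc2)no1` differs from compound 3 by 5-(tert-butyl)-1,2-oxazol-3-yl in place of 3,5-dichlorophenyl on an amide-type nitrogen. For the measured compounds named here, no measured step swaps the phenyl for a heteroaryl group, so the three aryl variations, none of which moved the number far, are the only guide. From compound 3 the expected step is no change at the digits printed from compound 3 to compound 4 (within the scatter), of no clear size beyond the scatter. Compound 4 is therefore estimated at 1300 nM, with a range from 400 nM to 4500 nM.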

Compound 4, half-maximal inhibitory concentration: 34 nM
Compound 4: middle estimate off by 38-fold (1.58 log units), on the high side; measured number outside the range, below it.
By their numbers in this assay, from the lowest: compound 4; then compounds 2, 3 and 1 (each within the scatter of the next, the first and the last beyond it).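

The steps of a 38-fold lower number from compound 3 to compound 4 (1.58 log units; beyond the scatter) and a 29-fold lower number from compound 2 to compound 4 (1.46 log units; beyond the scatter) and a 69-fold lower number from compound 1 to compound 4 (1.84 log units; beyond the scatter) show that this amide-type nitrogen tolerates far larger changes in the number than the substituted phenyl groups alone revealed. 5-(tert-butyl)-1,2-oxazol-3-yl stands clearly apart from all three phenyl groups, whose own differences were small by comparison.

As far as these compounds go, whether the tert-butyl or the 1,2-oxazole ring carries the shift stays open, since the change replaces both the ring and its substituents at once. A 4-tert-butylphenyl group or a 5-methyl-1,2-oxazol-3-yl group would separate the two, and nothing given here explains the shift.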